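This account rests on a few compounds, and the source may have more. Where it says the series, first, only, none or still open, it means among the compounds named here.

Working notes on the series. Compound 1 `O=c1c(CCO)c(-c2ccccc2Cl)c2cc(Cl)ccc2n1-c1c(F)cccc1F` in an ADME assay on HepG2 2.2.15 cells (Homo sapiens) for cytotoxicity (on this read-out lower numbers stand for higher toxicity in this test and higher numbers for lower toxicity in this test), gives only a limit, > 2300000 nM (the limit of > 2300000 nM in this assay, at which 1 of the 2 values shown sits). Compound 2 `COCC(=O)OCCc1c(-c2ccccc2Cl)c2cc(Cl)ccc2[nH]c1=O` gives 74000 nM in this assay, the only number shown in the series. Compound 1 contributes only a limit, so compound 2 stands alone as a measured point. Compound 3 `O=C(OCCc1c(-c2ccccc2Cl)c2cc(Cl)ccc2[nH]c1=O)c1cccnc1` has not yet been measured in this assay. It differs from compound 2 in one place: pyridin-3-yl in place of methoxymethyl on a carbonyl carbon. Among the measured compounds shown here, no step between measured compounds is available, so the size of this change cannot be read off the series. The expectation is a step from compound 2 to compound 3 that stays within the scatter, with no set direction, estimated as a 1.1-fold higher number from compound 2 to compound 3 (0.03 log units; within the scatter). Compound 3 is therefore estimated at 80000 nM in this assay, with a range from 30000 nM to 220000 nM.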

Compound 3, half-maximal cytotoxic concentration: 170000 nM
Compound 3: the middle estimate sits 2.1-fold (0.33 log units) below what was measured; the measured number falls inside the stated range.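

Among the compounds shown here, the first readable step falls on this carbonyl carbon: in this assay, pyridin-3-yl in place of methoxymethyl gives a 2.3-fold higher number from compound 2 to compound 3 (0.36 log units; beyond the scatter), a modest change beyond the scatter. This position therefore affects the read-out, and here the aromatic ring moves the number towards lower toxicity in this test rather than higher. No measured property in the series bears on the cause of this step.

As far as these compounds go, whether the ring nitrogen matters remains open, as does whether phenyl, an amine or a longer chain on the same carbonyl carbon would move the number in the same direction. For the compounds shown here, compound 1 remains a limit, > 2300000 nM, and differs from compound 2 in more than one place, so no step to it can be read.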